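Swapping a side chain on a piperazine amide

The source may hold more compounds than are shown below. What is called first, only, known or untested is meant among the compounds shown, and "the series" means these compounds.

In a functional assay on MDA-MB-231 cells (Homo sapiens) for inhibition, read by CellTiter-Glo, with a stated time of 72 h (a lower number here means that less compound is tolerated, a higher number that more compound is tolerated), compound 1 (`CC1=C(CC(=O)NCCN(C)C)c2cc(F)ccc2/C1=C\c1ccc(S(C)(=O)=O)cc1`) gives 37500 nM and compound 2 (`CC1=C(CC(=O)N2CCN(CCCN(C)C)CC2)c2cc(F)ccc2/C1=C\c1ccc([S+](C)[O-])cc1`) gives 46200 nM on this test. These two values lie within the usual scatter of each other, so compound 2 stands level with compound 1 on the numbers available.

The next compound is compound 3 (`CC1=C(CC(=O)N2CCN(c3ccncc3)CC2)c2cc(F)ccc2/C1=C\c1ccc([S+](C)[O-])cc1`), which differs from compound 2 in one place: pyridin-4-yl in place of 3-(dimethylamino)propyl on an amine nitrogen in a ring is the full count of the change. In words, pyridin-4-yl stands in place of 3-(dimethylamino)propyl on an amine nitrogen in a ring.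

Within the data shown here, no measured pair here differs in only one place, so the data give no direct size for such a swap. Compound 1 and compound 2 differ in more than one place and still sit within the scatter of each other, which argues against expecting a large move in this assay for compound 3. A small shift toward a lower number is expected, not clearly beyond the scatter. The estimated change is a 1.8-fold lower number from compound 2 to compound 3 (0.27 log units; within the scatter) in this reading. Compound 3 is expected to give about 25000 nM with an estimated range from 8000 nM to 60000 nM on this test.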

Compound 3, half-maximal cytotoxic concentration: 22700 nM
The estimate for compound 3 lay 1.1-fold (0.04 log units) above the measured number; the range from low to high includes it.
By their numbers in this assay, from the lowest: compounds 3, 1 and 2 (each within the scatter of the next, the first and the last beyond it).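

In this assay the swap of 3-(dimethylamino)propyl for pyridin-4-yl on an amine nitrogen in a ring gives a 2.0-fold lower number from compound 2 to compound 3 (0.31 log units; beyond the scatter) and provides the first direct measure of a single change at this position, showing that the group there can move the number, though only modestly. The two groups match in their counts of heavy atoms, hydrogen-bond donors and hydrogen-bond acceptors, and neither carries a net charge, so these counts do not distinguish them; the listed difference is an open chain against a six-membered aromatic ring. No measurement shown here accounts for the step.

A single pair cannot show whether the step follows from adding the aromatic ring or from losing the dimethylamino end of the chain. On these data alone, a plain phenyl ring or a shorter chain such as 2-(dimethylamino)ethyl at the same nitrogen would help separate those two readings, and the size of the effect with other groups at this position remains open.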